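The compounds below may be only part of what the source reports. "The series", "measured", "known", "first", "only" and "open" are said of these compounds alone.

Working notes on the series, taken in an assay on A549 cells for inhibition of transcription factor p65 (Homo sapiens), read by fluorescence, with a stated time of 2 h; a higher number here means a weaker inhibitor, a lower number a stronger inhibitor.

Going by the values given here, compound 2 `COc1ccccc1/C=C/C(=O)c1cccc(-c2cccc(F)c2)c1` is the only member of the pair with a numerical result: in this assay compound 2 gives 35300 nM. Compound 1 `COc1ccc(/C=C/C(=O)c2cccc(-c3ccc(F)cc3)c2)cc1` returns only a limit of the assay: in this assay compound 1 reads > 50000 nM, a limit and not a number. Among the compounds with values here, the state of the set is therefore one number and one limit (the limit of > 50000 nM in this assay, at which 1 of the 2 values shown sits), so compound 2 stands as the single point from which any step can be reckoned, and no measured step between two compounds exists yet.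

Compound 3 `COc1ccc(/C=C/C(=O)c2cccc(-c3cccc(F)c3)c2)cc1` has the same atoms as compound 2 joined differently: 4-methoxyphenyl in place of 2-methoxyphenyl on a double-bonded chain carbon bound to a double-bonded chain carbon. No measured pair in this set isolates this change, so the direction of the step in this assay cannot be read from the shown data; the expectation is for a step no larger than the usual scatter, with the risk that the result also ends as a limit. On that basis the expected step is a 1.3-fold higher number from compound 2 to compound 3 (0.11 log units; within the scatter). The estimate for compound 3 in this assay is 45000 nM, within 18000 nM to 110000 nM.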

Compound 3, half-maximal inhibitory concentration: > 50000 nM
Compound 3: no number, only a limit (the forecaster's own chance of this, stated with the estimate: 45%); middle value at least 1.1-fold (0.04 log units) away from the limit.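

In this assay, going by these compounds alone, 4-methoxyphenyl in place of 2-methoxyphenyl on a double-bonded chain carbon bound to a double-bonded chain carbon gives the first measured step: an at least 1.4-fold higher number from compound 2 to compound 3 (0.15 log units; that floor lies within the scatter). This step has only a floor, since the result for compound 3 is a limit of the assay and not a number, so the change is shown to give no measurable number in this assay, while its true size remains unknown and could exceed the floor. The other change, 3-fluorophenyl in place of 4-fluorophenyl on an aromatic carbon, cannot be read between compound 1 and compound 3, since both results are limits, and most of the set now rests there: the limit of > 50000 nM in this assay, at which 2 of the 3 values shown sit.

On these data alone, it remains open whether the step at the methoxy position truly exceeds the usual scatter, and whether the fluorine placement matters at all when the 4-methoxyphenyl group is held. As far as these compounds go, it is also open whether an amine or a carboxylic acid in place of the methoxy group would give a number clear of the limit and allow these steps to be sized.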